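The source may hold more compounds than are shown below. What is called first, only, known or untested is meant among the compounds shown, and "the series" means these compounds.

Of the compounds shown here, three built on a shared core have been tested in a functional assay on HL-60 cells (Homo sapiens) for antiproliferative activity, with a stated time of 72 h; on this read-out higher numbers stand for weaker inhibition of growth and lower numbers for stronger inhibition of growth. Among the compounds with values here, compound 1 (`C=C(CCCC)C(=O)c1ccc(OC(C)C(=O)O)c(C)c1C`) gives 12100 nM, the only true number among them. Compound 2 (`C=C(CC)C(=O)c1ccc(OCC(=O)O)cc1C`) reads > 60000 nM, which is a limit of the assay and not a number. Compound 3 (`C=C(C)C(=O)c1ccc(OC(C)C(=O)O)cc1C`) reads > 60000 nM, which is likewise a limit. Compound 3 therefore has no measured number of its own and stands at the limit of > 60000 nM in this assay, at which 2 of the 3 values shown sit.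

Compound 4 (`C=C(CC)C(=O)c1ccc(OC(C)C(=O)O)cc1C`) departs from compound 3 in one place: methyl in place of hydrogen on a saturated chain carbon bound to a double-bonded chain carbon. This puts methyl in place of hydrogen on a saturated chain carbon bound to a double-bonded chain carbon, and cut one bond further out, the same difference reads methyl to ethyl.

Within the data shown here, no measured pair in this assay gauges this change, so any forecast is loose. A modest step toward stronger inhibition of growth is expected, and it may not clear the usual scatter. Compound 4 could well remain at the limit. The estimated change is an at least 1.3-fold lower number from compound 3 to compound 4 (0.12 log units; that floor lies within the scatter). For compound 4 the expected value is 45000 nM, with an estimated range from 20000 nM to 80000 nM.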

Compound 4, concentration for 50% growth inhibition: > 60000 nM
Compound 4: a limit, no number (the forecaster's own chance of this, stated with the estimate: 55%); at least 1.3-fold (0.12 log units) between middle value and limit.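

In this assay compound 4 gives > 60000 nM, which is a limit of the assay and not a number. The steps linking compound 4 to compound 2 and to compound 3 cannot be read, as all three compounds sit at the same limit: the limit of > 60000 nM in this assay, at which 3 of the 4 values shown sit.

The compounds shown leave open whether methyl in place of hydrogen at either place changes growth inhibition at all.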